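A few compounds are considered here, and "the series" means these few. Any claim that something is new, unique, unknown or untested is made for them only; others in the source may bear on it.

Measured in an ADME assay on microsomes from liver (Mus musculus) for metabolic stability, read by LC-MS, with a stated time of 30 min, tested at 1 uM; on this read-out lower numbers stand for a less stable compound and higher numbers for a more stable compound:

Compound 1 `O=C(NCc1ccc(S(=O)(=O)c2cc(F)cc(F)c2)cc1)c1cc2cnccc2[nH]1`: 63%
Compound 2 `O=C(NCc1ccc(S(=O)(=O)c2ccccc2)cc1)c1ccc2nncn2c1`: 47%
Compound 3 `O=C(NCc1ccc(S(=O)(=O)c2ccccc2)cc1)c1cn2ccnc2cn1`: 13%

Compound 3 stands lowest of the three numbers in this assay, with a number 34 percentage points lower from compound 2 to compound 3 (beyond the scatter) as the nearest step and compound 1 at 63% further above it.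

Compound 4 `O=C(NCc1ccc(S(=O)(=O)c2ccccc2)cc1)c1cc2cnccc2[nH]1` differs from compound 3 by a group of 9 heavy atoms (7 carbon, 2 nitrogen; one five-membered aromatic ring with 1 hetero atom, one six-membered aromatic ring with 1 hetero atom) in place of a group of 9 heavy atoms (6 carbon, 3 nitrogen; one five-membered aromatic ring with 2 hetero atoms, one six-membered aromatic ring with 2 hetero atoms), on a carbonyl carbon. Among the measured compounds shown here, the one measured step that bears on this is the exchange of the same group on the carbonyl carbon, a number 34 percentage points lower from compound 2 to compound 3 (beyond the scatter), a large move on changing that group. Compound 1 carries the group that enters here and gives 63%. A step upward beyond the scatter is therefore expected, a number 45 percentage points higher from compound 3 to compound 4 (beyond the scatter). Compound 4 is estimated at 58%, with a range from 40% to 75%.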

Compound 4, percent of the compound remaining: 54%
Compound 4: middle estimate off by 4 percentage points, on the high side; low and high end bracket the measured number.
By their numbers in this assay, from the lowest: compound 3; then compounds 2, 4 and 1 (each within the scatter of the next, the first and the last beyond it).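

In this assay, the group on the carbonyl carbon makes a large difference, with a number 41 percentage points higher from compound 3 to compound 4 (beyond the scatter), yet a number 7 percentage points higher from compound 2 to compound 4 (within the scatter), so only the group of compound 3 stands apart among these three. On the sulfonyl sulfur, phenyl in place of 3,5-difluorophenyl gives a number 9 percentage points lower from compound 1 to compound 4 (within the scatter), so this pair shows no separation. Nothing available explains the low number of compound 3.

Going by these compounds, whether that low number persists with 3,5-difluorophenyl on the sulfonyl sulfur remains open. So does the reading with a pyridine or a morpholine on the carbonyl carbon.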